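Ester variant of compound 2: working notes on the series

This account rests on a few compounds, and the source may have more. Where it says the series, first, only, none or still open, it means among the compounds named here.

Measured compounds:
Compound 1 `CC(=O)Cn1nnc(Cc2ccc(-c3ccccc3)cc2)n1`: in an assay for inhibition of Fatty-acid amide hydrolase 1 (Rattus norvegicus) (a higher number here means a weaker inhibitor, a lower number a stronger inhibitor), compound 1 gives > 50000 nM, which is a limit of the assay and not a number.
Compound 2 `CN(C)C(=O)Cn1nnc(CNC(=O)c2ccc(-c3ccccc3)cc2)n1`: in this assay compound 2 gives > 50000 nM, again a limit of the assay.
Compound 3 `CC(=O)Cn1nnnc1CNC(=O)c1ccc(-c2ccccc2)cc1`: in this assay compound 3 gives > 50000 nM, also a limit of the assay.

Among the measured compounds shown here, compound 2 therefore stands where every value so far stands: at the limit of > 50000 nM in this assay, at which 3 of the 3 values shown sit. For the measured compounds named here, nothing among the measured compounds separates them by a single change, so compounds 1, 2 and 3 show only that all three reach the limit and no more. No ordering among them can be read from this.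

Compound 4 `COC(=O)Cn1nnc(CNC(=O)c2ccc(-c3ccccc3)cc2)n1` is the next candidate. Relative to compound 2 the change is methoxy in place of dimethylamino on a carbonyl carbon, or read one bond further out, dimethylcarbamoyl to methoxycarbonyl.

Given that the three measured compounds all sit at the limit, no step beyond the usual scatter is expected from compound 2 to compound 4, and the estimated step of a number no higher from compound 2 to compound 4 (the limit leaves the size open) is set accordingly. Compound 4 is therefore expected to give about 50000 nM in this assay, with a range of 15000 nM to 200000 nM, and most likely the assay will again report only a limit.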

Compound 4, half-maximal inhibitory concentration: > 50000 nM
Compound 4 ended at the assay's limit; the forecaster's own chance of this, stated with the estimate: 80%; the middle value lies on the limit itself.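

Compound 4 sits with compound 2 at the limit of the assay, so no step can be read between them for methoxy in place of dimethylamino on a carbonyl carbon: the limit of > 50000 nM in this assay, at which 4 of the 4 values shown sit.

The compounds shown leave open whether any of them has a value in this assay that is a number rather than a limit.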